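The source may report more compounds than this note shows. Statements on the series, on what has been measured and on what is new or still open speak of the compounds shown alone.

Working notes on the series. The shared core is seen in compound 1 `Fc1cccc(-c2nc(Nc3ccccc3)c3ccccc3n2)c1` and in compound 2 `Fc1cccc(-c2nc(Nc3cccc(Cl)c3)c3cc(F)ccc3n2)c1`. In a functional assay on HT29-AK cells (Homo sapiens) for cytotoxicity, read by MTT assay, with a stated time of 48 h (a higher number here means a weaker inhibitor, a lower number a stronger inhibitor), compound 1 gives only a limit of the assay, > 50000 nM, not a number. In this assay compound 2 likewise gives only a limit, > 50000 nM. Among the compounds with values here, compound 2 therefore stands at a limit, as does the one other value shown; both sit at the limit of > 50000 nM in this assay, at which 2 of the 2 values shown sit, so no measured step within the set can be read, and no direction of change is established by the numbers. Compound 3 `Nc1ccccc1Nc1nc(-c2cccc(F)c2)nc2ccc(F)cc12` is not yet measured. It differs from compound 2 in one place: 2-aminophenyl in place of 3-chlorophenyl on a nitrogen on an aromatic ring. Within the data shown here, with no measured step to rest on, the change from compound 2 to compound 3 is expected to produce no step beyond the scatter in this assay, the expected step being an at least 1.2-fold lower number from compound 2 to compound 3 (0.09 log units; that floor lies within the scatter). Compound 3 is thus estimated at about 40000 nM in this assay, with a range from 8000 nM to 150000 nM, and a real chance that only a limit is reported again.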

Compound 3, half-maximal inhibitory concentration: > 50000 nM
Compound 3: no number, only a limit (the forecaster's own chance of this, stated with the estimate: 60%); middle value at least 1.2-fold (0.09 log units) away from the limit.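

In this assay compound 3 gives only a limit of the assay (> 50000 nM). No step from compound 2 to compound 3 can be read, since both stand at the same limit: the limit of > 50000 nM in this assay, at which 3 of the 3 values shown sit.
The compounds shown leave open whether any change on the shared core yields a measured number in this assay and how 2-aminophenyl compares with 3-chlorophenyl there.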